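The source may report more compounds than this note shows. Statements on the series, on what has been measured and on what is new or still open speak of the compounds shown alone.

Measured compounds in a functional assay on NCI/ADR-RES cells (Homo sapiens) for inhibition, read by sulforhodamine B assay, with a stated time of 48 h; on this read-out higher numbers stand for weaker inhibition of growth and lower numbers for stronger inhibition of growth:
compound 1 `Nc1cc(N)c2nc(-c3ccccc3)c(Oc3ccc(Cl)c(Cl)c3)nc2c1` — 11700 nM
compound 2 `CCOC(=O)[C@H](CCC(=O)O)NC(=O)c1ccc(Oc2nc3cc(N)cc(N)c3nc2-c2ccccc2)cc1` — 27500 nM
compound 3 `COc1ccc(CNc2nc3cc(N)cc(N)c3nc2-c2ccccc2)cc1` — 22900 nM

Of the compounds shown here, three sharing one core have been measured. Compound 1 gives the lowest number of the three in this assay, but the gap to compound 3 is within the scatter of the assay, so the two cannot be told apart on these figures. The number for compound 2 lies beyond the scatter above that of compound 1, so compound 2 is the weaker of that pair in this assay.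

The next compound, compound 4 `Nc1cc(N)c2nc(-c3ccccc3)c(Sc3ccc(Cl)c(Cl)c3)nc2c1`, has not yet been measured. Among the measured compounds shown here, its one change from compound 1 is (3,4-dichlorophenyl)sulfanyl in place of 3,4-dichlorophenoxy on an aromatic carbon. For the measured compounds named here, no pair of measured compounds differs in only this way, so there is no measured step to lean on; the change keeps the same ring, the same two chlorine substituents and the same count of atoms and acceptors, and only the linking atom differs. On this basis the step from compound 1 to compound 4 in this assay is expected to be small, in no fixed direction, and likely within the scatter. Compound 4 is therefore estimated at 10000 nM, with a range of 4000 nM to 25000 nM, which corresponds to an expected step of a 1.2-fold lower number from compound 1 to compound 4 (0.07 log units; within the scatter).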

Compound 4, concentration for 50% growth inhibition: 19100 nM
Estimate against measurement, compound 4: 1.9-fold (0.28 log units) below; the measured number falls inside the stated range.
By their numbers in this assay, from the lowest: compounds 1, 4, 3 and 2 (each within the scatter of the next, the first and the last beyond it).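

Among the compounds shown here, the pair compound 1 and compound 4 gives the first measured step at this position, on an aromatic carbon next to the ring nitrogen and ortho to a phenyl group: in this assay, (3,4-dichlorophenyl)sulfanyl in place of 3,4-dichlorophenoxy gives a 1.6-fold higher number from compound 1 to compound 4 (0.21 log units; within the scatter) and nothing more. On these figures, then, the linking atom on the dichlorophenyl group can be sulfur or oxygen without a step that stands out from the scatter, and compound 1 and compound 4 cannot be told apart in this assay on this read-out. No measurement at hand bears on what lies behind this step.

The compounds shown leave open whether the same holds for other links at this position, such as an amine, a sulfonyl or a methylene link carrying the same 3,4-dichlorophenyl group. For the compounds shown here, they also leave open what the two chlorine atoms contribute, since no pair here sets them against hydrogen, methoxy or trifluoromethyl on that ring, and the step rests on one exchange in a single cell line.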